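One Carbon More on the Hydroxamate Chain

A few compounds are considered here, and "the series" means these few. Any claim that something is new, unique, unknown or untested is made for them only; others in the source may bear on it.

Measured in a functional assay on MDA-MB-231 cells (Homo sapiens) for inhibition, read by MTT assay, with a stated time of 72 h; a lower number here means a stronger inhibitor, a higher number a weaker inhibitor:
compound 1 `Nc1ncnc2c1c(-c1cnc3[nH]ccc3c1)nn2CCCCCCCCC(=O)NO`: 11000 nM
compound 2 `Nc1nc2cc(-c3nn(CCCC(=O)NO)c4ncnc(N)c34)ccc2o1`: 19500 nM
compound 3 `Nc1ncnc2c1c(-c1cnc3[nH]ccc3c1)nn2CCCCC(=O)NO`: > 50000 nM (a limit)

In this assay, compound 1 at 11000 nM and compound 2 at 19500 nM lie within the scatter of each other. Compound 3 gives only a limit, > 50000 nM. Among the measured compounds shown here, compound 1 therefore stands level with the one other compound that has a number.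

The next compound, compound 4 `Nc1ncnc2c1c(-c1cnc3[nH]ccc3c1)nn2CCCCCCCCCC(=O)NO`, extends the chain of compound 1: (hydroxycarbamoyl)methyl in place of hydroxycarbamoyl on a saturated chain carbon, eight bonds along the chain from an aromatic nitrogen. Here (hydroxycarbamoyl)methyl stands in place of hydroxycarbamoyl on a saturated chain carbon, eight bonds along the chain from an aromatic nitrogen.

For the measured compounds named here, only one measured step bears on this change, and it concerns the same chain: an at least 4.5-fold higher number from compound 1 to compound 3 (0.65 log units; beyond the scatter). That step is beyond the scatter, but it exchanges hydroxycarbamoyl for 4-(hydroxycarbamoyl)butyl, a far larger change than the one at hand. Going by the values given here, no measured compound has a chain longer than that of compound 1, so the direction rests on this single step.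

The expected result in this assay is a small move to a lower number, within the scatter: a 1.3-fold lower number from compound 1 to compound 4 (0.11 log units; within the scatter). The estimate for compound 4 is 8500 nM, with an expected range of 3500 nM to 20000 nM.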

Compound 4, half-maximal inhibitory concentration: 10100 nM
Compound 4: the middle estimate sits 1.2-fold (0.07 log units) below what was measured; low and high end bracket the measured number.
By their numbers in this assay, from the lowest: compounds 4, 1 and 2 (each within the scatter of the next). At a limit, above all of these: compound 3.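

In this assay, (hydroxycarbamoyl)methyl in place of hydroxycarbamoyl on a saturated chain carbon, eight bonds along the chain from an aromatic nitrogen, leaves the reading effectively unchanged, with a 1.1-fold lower number from compound 1 to compound 4 (0.04 log units; within the scatter). Among the compounds shown here, the earlier compounds held no chain longer than that of compound 1, so this is the first evidence that the advantage of the long chain over the short chain of compound 3 survives one further carbon, and an at least 4.9-fold lower number from compound 3 to compound 4 (0.69 log units; beyond the scatter) confirms that separation with the new compound. For compound 3 the starting point of that step is a limit and not a number: the limit of > 50000 nM in this assay, at which 1 of the 4 values shown sits.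

The compounds shown leave open whether a still longer chain would hold this level or lose it, since compound 4 marks the end of the series here. They also do not tell how the numbers run at chain lengths between those of compound 3 and compound 1, or what a carboxylic acid would give in place of the hydroxycarbamoyl group at the end of the chain.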